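The source may hold more compounds than are shown below. What is called first, only, known or untested is meant among the compounds shown, and "the series" means these compounds.

Series notes: hydroxamic acids on a shared core, followed in an assay on Sf9 cells for inhibition of protein deacetylase HDAC6 (Homo sapiens), read by fluorescence, with a stated time of 40 min; on this read-out lower numbers stand for stronger inhibition and higher numbers for weaker inhibition.

Compound 1 `Cc1ccc(-c2nc(CNc3ccc(C(=O)NO)cc3)n(-c3ccccc3)n2)cc1` carries a 4-methylphenyl group on the core; in this assay compound 1 gives 224 nM. Compound 2 `O=C(NO)c1ccc(NCc2nc(-c3cccc(Cl)c3)nn2-c2ccccc2)cc1` carries a 3-chlorophenyl group in the same position; in this assay compound 2 gives 115 nM. Among the measured compounds shown here, the one measured step, a 1.9-fold lower number from compound 1 to compound 2 (0.29 log units; within the scatter), is within the scatter. On the two numbers shown compound 2 stands lowest, with compound 1 nearest and within the scatter of it, so no order between the two can be claimed.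

Compound 3 `O=C(NO)c1ccc(NCc2nc(-c3ccc(Cl)cc3)nn2-c2ccccc2)cc1` is the next member. Compared with compound 2 the change is 4-chlorophenyl in place of 3-chlorophenyl on an aromatic carbon. For the measured compounds named here, no measured step moves the chlorine between these two positions of the phenyl group, so the only guide is the step from compound 1 to compound 2, which exchanged one aryl group for another without leaving the scatter. A step of similar, small size is therefore expected, with no direction that can be read from the data.

For compound 3 in this assay the expected value is 140 nM, with a range from 50 nM to 400 nM; the expected step of a 1.2-fold higher number from compound 2 to compound 3 (0.09 log units; within the scatter) is not beyond the scatter.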

Compound 3, half-maximal inhibitory concentration: 181 nM
Compound 3: the middle estimate sits 1.3-fold (0.11 log units) below what was measured, and the stated range covers the measured number.
By their numbers in this assay, from the lowest: compounds 2, 3 and 1 (each within the scatter of the next).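

In this assay, the exchange of 3-chlorophenyl for 4-chlorophenyl on the aromatic carbon between two ring nitrogen atoms keeps the same atoms and changes only where the chlorine is attached, and it gives a 1.6-fold higher number from compound 2 to compound 3 (0.20 log units; within the scatter), so these two chlorine placements are not told apart at this position. The exchange of chloro for methyl on the phenyl group, with the 4-substitution kept, gives a 1.2-fold lower number from compound 1 to compound 3 (0.09 log units; within the scatter), which adds that 4-methylphenyl and 4-chlorophenyl are not told apart here either, and all three compounds therefore stay unordered. Nothing available here bears on the reason for these numbers.

On these data alone, it remains open whether this position responds at all to a larger change, such as an amine or a carboxylic acid on the phenyl group, a longer alkyl chain, or a pyridine ring in place of the phenyl group. The compounds shown also leave open whether a change at the other sites of the shared core, including its phenyl group on the ring nitrogen, would produce a step beyond the scatter.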